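Aryl swap on the enone chain of compound 3

A few compounds are considered here, and "the series" means these few. Any claim that something is new, unique, unknown or untested is made for them only; others in the source may bear on it.

Measured so far: compound 1 `CCOc1ccc(/C=C(\C(=O)c2ccc(Cl)cc2)S(=O)(=O)Cc2ccc(C)cc2)cc1OC`, 10000 nM; compound 2 `Cc1ccc(CS(=O)(=O)/C(=C/c2ccc(C)s2)C(=O)c2ccc(Cl)cc2)cc1`, 25000 nM; compound 3 `Cc1ccc(CS(=O)(=O)/C(=C/c2ccccc2Br)C(=O)c2ccc(Cl)cc2)cc1`, 25000 nM, all in a functional assay on DU-145 cells (Homo sapiens) for inhibition, read by trypan blue exclusion, with a stated time of 96 h; a higher number here means a weaker inhibitor of growth, a lower number a stronger inhibitor of growth.

Compound 3 is level with compound 2 at the digits shown, the two together the highest numbers of the three; compound 1 sits apart, with a 2.5-fold higher number from compound 1 to compound 3 (0.40 log units; beyond the scatter). Compound 4 `Cc1ccc(CS(=O)(=O)/C(=C/c2ccc(Cl)cc2)C(=O)c2ccc(Cl)cc2)cc1` differs from compound 3 in one place: 4-chlorophenyl in place of 2-bromophenyl on a double-bonded chain carbon bound to a double-bonded chain carbon. Among the compounds with values here, the steps that bear on this are no change at the digits printed from compound 2 to compound 3 (within the scatter), a 2.5-fold higher number from compound 1 to compound 2 (0.40 log units; beyond the scatter) and a 2.5-fold higher number from compound 1 to compound 3 (0.40 log units; beyond the scatter), so the aryl group on this chain carbon has moved the number by at most a modest amount. A small lowering toward compound 1 is expected, a 1.7-fold lower number from compound 3 to compound 4 (0.22 log units; within the scatter), since compound 1, also a para-substituted phenyl, gives 10000 nM. For compound 4 the estimate is 15000 nM, range 6000 nM to 40000 nM.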

Compound 4, concentration for 50% growth inhibition: 25000 nM
Compound 4: the middle estimate sits 1.7-fold (0.22 log units) below what was measured, and the stated range covers the measured number.
By their numbers in this assay, from the lowest: compound 1; then compounds 2, 3 and 4 (each within the scatter of the next).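

In this assay, 4-chlorophenyl on this double-bonded chain carbon reads level with 2-bromophenyl (no change at the digits printed from compound 3 to compound 4 (within the scatter)) and with 5-methylthiophen-2-yl (no change at the digits printed from compound 2 to compound 4 (within the scatter)), so compounds 2, 3 and 4 form one group despite the different rings and halogens. Compound 1 alone stands apart (a 2.5-fold higher number from compound 1 to compound 4 (0.40 log units; beyond the scatter)), so sharing a substituent at the 4-position of the phenyl does not bring compound 4 to the number of compound 1. No evidence bears on this gap.

Still open, going by these compounds, is whether the gap follows the ethoxy group, the methoxy group or both. Also open, on these data alone, is what an amine or a carboxylic acid on this phenyl would give.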